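Imidazolylmethyl in place of pyrrolidinylmethyl on a quinoline sulfonamide

The source may report more compounds than this note shows. Statements on the series, on what has been measured and on what is new or still open speak of the compounds shown alone.

Compound 1 `CCN(Cc1ccc(-c2ccnc3ccc(-c4cnc(OC)c(NS(=O)(=O)c5ccc(F)cc5F)c4)cc23)cc1)C1CCCCC1`: 20.2 nM
Compound 2 `COc1ncc(-c2ccc3nccc(-c4ccc(CN5CCCC5)cc4)c3c2)cc1NS(=O)(=O)c1ccc(F)cc1F`: 37.5 nM
Compound 3 `COc1ncc(-c2ccc3nccc(-c4ccc(CN5CCN(C)CC5)cc4)c3c2)cc1NS(=O)(=O)c1ccc(F)cc1F`: 13.3 nM

Three compounds share one core and differ only in the group on a saturated chain carbon bound to an aromatic carbon. In a functional assay on A549 cells (Homo sapiens) for cytotoxicity, read by MTT assay, with a stated time of 72 h (on this read-out higher numbers stand for weaker inhibition and lower numbers for stronger inhibition), compound 2 has the highest number of the three. The step of a 1.9-fold higher number from compound 1 to compound 2 (0.27 log units; within the scatter) is within the scatter, while a 2.8-fold lower number from compound 2 to compound 3 (0.45 log units; beyond the scatter) and a 1.5-fold lower number from compound 1 to compound 3 (0.18 log units; within the scatter) show that compound 3 sits at the lower end of this small set.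

Compound 4 `COc1ncc(-c2ccc3nccc(-c4ccc(Cn5ccnc5)cc4)c3c2)cc1NS(=O)(=O)c1ccc(F)cc1F` is not yet measured. It differs from compound 2 as follows: 1H-imidazol-1-yl in place of pyrrolidin-1-yl on a saturated chain carbon bound to an aromatic carbon. Going by the values given here, none of the measured steps bears directly on this change, since all three measured groups are saturated amines and the entering group is an aromatic ring. Among the compounds with values here, the measured steps among them span only a modest range, so no large movement is assumed, but with no precedent for the aromatic group the uncertainty is wide. Compound 4 is expected to give 60 nM in this assay, with a range from 20 nM to 200 nM, which means an expected step of a 1.6-fold higher number from compound 2 to compound 4 (0.20 log units; within the scatter).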

Compound 4, half-maximal inhibitory concentration: 30.8 nM
Beside the measured number, compound 4's estimate is 1.9-fold (0.29 log units) above it; the measured number falls inside the stated range.
By their numbers in this assay, from the lowest: compounds 3, 1, 4 and 2 (each within the scatter of the next, the first and the last beyond it).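

In this assay the aromatic 1H-imidazol-1-yl group on a saturated chain carbon bound to an aromatic carbon reads much like the saturated pyrrolidin-1-yl group, with a 1.2-fold lower number from compound 2 to compound 4 (0.09 log units; within the scatter) and so no real change. Against the other two groups the result is mixed: there is a 1.5-fold higher number from compound 1 to compound 4 (0.18 log units; within the scatter) and this also stays within the scatter, whereas a 2.3-fold higher number from compound 3 to compound 4 (0.36 log units; beyond the scatter) leaves 4-methylpiperazin-1-yl as the only group here that separates from the imidazole. This position therefore accepts an aromatic ring as well as saturated amines within a narrow span of numbers, and nothing in the data shown accounts for the differences.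

The compounds shown leave open how a 1H-pyrazol-1-yl or morpholin-4-yl group would read at this place. They also leave open what a longer chain in place of the single saturated carbon would do.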